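Methyl to Methoxy on a Fused Ring Toward Crabgrass Inhibition

The source may hold more compounds than are shown below. What is called first, only, known or untested is meant among the compounds shown, and "the series" means these compounds.

Measured compounds:
compound 1 `Cc1cc(O)nc(NC(=S)NC(=O)c2c(-c3ccc(Cl)cc3Cl)noc2C)n1` — -6.24%
compound 2 `COc1cc(C)nc2n/c(=N/C(=O)c3c(-c4ccc(Cl)cc4Cl)noc3C)sn12` — 50.3%

Two compounds share a dichlorophenyl-isoxazole amide unit and were tested in a functional assay on the whole organism for inhibition, with Digitaria ciliaris as the target, with a stated time of 72 h, tested at 10 mg/L; on this read-out lower numbers stand for less inhibition of growth and higher numbers for more inhibition of growth at the one concentration tested. Compound 1 gives -6.24%, a number near zero. Compound 2 gives 50.3%, the higher of the two values, and the gap to compound 1 lies beyond the usual scatter. Among the measured compounds shown here, the two compounds differ in several places at once, so their values show only that compound 2 inhibits the grass while compound 1 does not.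

Compound 3 `COc1cc(OC)n2s/c(=N\C(=O)c3c(-c4ccc(Cl)cc4Cl)noc3C)nc2n1` has not yet been measured. It keeps the whole framework of compound 2 and differs in a single place: methoxy in place of methyl on an aromatic carbon. For the measured compounds named here, with only one measured neighbour and no comparable step among the measured compounds, there is nothing in these data that points to a strong shift in either direction. A change this small is expected to leave the value near that of compound 2, with a step from compound 2 to compound 3 estimated at a number 5.3 percentage points lower from compound 2 to compound 3 (within the scatter). In this assay compound 3 is therefore expected to give 45%, within a range from 20% to 70%.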

Compound 3, percent growth inhibition at one concentration: 53.8%
Beside the measured number, compound 3's estimate is 8.8 percentage points below it; measured number inside the range.
By their numbers in this assay, from the lowest: compound 1; then compounds 2 and 3 (each within the scatter of the next).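

Methoxy in place of methyl on this aromatic carbon gives the first comparison here of compounds that differ in only one place, and in this assay the change reads as a number 3.5 percentage points higher from compound 2 to compound 3 (within the scatter). This position therefore accepts methoxy, with 2 heavy atoms and 1 hydrogen-bond acceptor, in place of methyl, with 1 heavy atom and 0 hydrogen-bond acceptors, with no difference in growth inhibition that stands out from the scatter. Nothing available here explains why the read-out holds steady across this change.

The compounds shown leave open whether other groups on this carbon, such as an amine, a carboxylic acid or a longer chain like ethoxy, would also keep the inhibition of crabgrass at this level, and whether the same holds for the other methoxy group of compound 3. With a single test concentration, they also leave open whether compound 2 and compound 3 would separate at lower concentrations, where a difference hidden at this dose could appear.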